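Dropping the methoxy from the chromanone core

This account rests on a few compounds, and the source may have more. Where it says the series, first, only, none or still open, it means among the compounds named here.

Measured in an assay on BTI cells for inhibition of Amine oxidase [flavin-containing] B (Homo sapiens), read by fluorescence, with a stated time of 20 min, tested at 1 uM; on this read-out higher numbers stand for more inhibition at the one concentration tested (going by the name of the read-out) and lower numbers for less inhibition:
- compound 1, `COc1cccc2c1OCC(C)(C)C2N`: 4.3%
- compound 2, `COc1cccc2c1C(=O)C(C)(C)CO2`: 5.9%
- compound 3, `C#CCNC1c2ccccc2OCC1(C)C`: 11.6%

Of the compounds shown here, three sharing a fused bicyclic core have been measured so far. In this assay compound 1 gives 4.3%, compound 2 gives 5.9% and compound 3 gives 11.6%. Compound 2 sits between the other two; the gap to compound 1 is the nearer and the gap to compound 3 the wider, but both lie within the scatter of the measurement, so the three numbers cannot be told apart.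

The next compound, compound 4, `CC1(C)COc2ccccc2C1=O`, is the unsubstituted counterpart of compound 2. The change from compound 2 to compound 4 is hydrogen in place of methoxy on an aromatic carbon. Among the compounds with values here, no measured pair shows the effect of this change, so nothing can be read off directly. Given that all three measured compounds cluster at low inhibition, the step from compound 2 to compound 4 is expected to stay within the scatter, and the estimate is a number 0.1 percentage points higher from compound 2 to compound 4 (within the scatter). For compound 4 the expected value is 6%, within a range from 0% to 16%.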

Compound 4, a percentage reported as inhibition, at one concentration (the size of the read-out at that concentration, not a potency): 9.2%
Compound 4: the middle estimate sits 3.2 percentage points below what was measured; the range from low to high includes it.
By their numbers in this assay, from the lowest: compounds 1, 2, 4 and 3 (each within the scatter of the next).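

In this assay, putting hydrogen in place of methoxy on this aromatic carbon gives a number 3.3 percentage points higher from compound 2 to compound 4 (within the scatter), so the first pair differing in one place cannot be told apart. The methoxy, with its hydrogen-bond acceptor and 2 heavy atoms, can therefore go from this carbon of the ketone core without a difference that the read-out can resolve at the single concentration tested, though this says nothing about potency. Nothing among the available data explains this result.

On these data alone, what a carboxylic acid or a longer chain such as propoxy would do on this same aromatic carbon remains open. As far as these compounds go, it is also open whether the same swap of methoxy for hydrogen would give a comparable step on the amine-bearing compound 1.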